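The source may hold more compounds than are shown below. What is called first, only, known or untested is meant among the compounds shown, and "the series" means these compounds.

Measured so far:
compound 1 `Cc1ccc2c(=O)c(CSC(=S)N(C(C)C)C(C)C)coc2c1` — 1400 nM
compound 2 `CCN(CC)C(=S)SCc1cc(=O)c2ccc(Cl)cc2o1` — 8700 nM

In a functional assay on HeLa cells (Homo sapiens) for antiproliferative activity, read by MTT assay, with a stated time of 72 h (on this read-out higher numbers stand for weaker inhibition and lower numbers for stronger inhibition), compound 2 has the higher of the two numbers; compound 1 sits lower, and that gap is beyond the scatter. Compound 3 `O=c1cc(CSC(=S)N2CCOCC2)oc2cc(Cl)ccc12` is the next step from compound 2, with morpholin-4-yl in place of diethylamino on a thiocarbonyl carbon. Within the data shown here, no pair of measured compounds shows this change on its own, so the size of the step is not known from the series. For compound 3 the expectation is a step of a 1.1-fold higher number from compound 2 to compound 3 (0.06 log units; within the scatter) in this assay, no larger than the scatter. Compound 3 is thus estimated at 10000 nM, within 3000 nM to 35000 nM.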

Compound 3, half-maximal inhibitory concentration: 33300 nM
The estimate for compound 3 lay 3.3-fold (0.52 log units) below the measured number, within the range that was stated.
By their numbers in this assay, from the lowest: compound 1; then compound 2; then compound 3.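

In this assay, among these compounds, the group on the thiocarbonyl carbon proves not to be neutral: morpholin-4-yl in place of diethylamino gives a 3.8-fold higher number from compound 2 to compound 3 (0.58 log units; beyond the scatter) and this is the first step that can be read on its own. The swap adds a ring and a hydrogen-bond acceptor together, so the step cannot be assigned to either one. No measurement at hand accounts for the step.

Piperidin-1-yl on the same carbon would separate the ring from the morpholine oxygen. As far as these compounds go, whether the step carries over to the core of compound 1 remains open.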